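From methoxy to methyl on the core of compound 1

This account rests on a few compounds, and the source may have more. Where it says the series, first, only, none or still open, it means among the compounds named here.

- compound 1 `COc1ccc(-c2[nH]c3ccc(OC)cc3c2C=O)cc1` with 180 nM
- compound 2 `COc1ccc(-c2[nH]c3cc(OC)ccc3c2C=O)cc1` with 160 nM
- compound 3 `COc1ccc(-c2[nH]c3cc(Cl)ccc3c2C=O)cc1` with 65 nM

In a functional assay on MCF7 cells (Homo sapiens) for antiproliferative activity, with a stated time of 5 days (on this read-out higher numbers stand for weaker inhibition and lower numbers for stronger inhibition), compound 1 at 180 nM and compound 2 at 160 nM lie within the scatter of each other, and compound 3 at 65 nM stands lower than both. The change to compound 4 `COc1ccc(-c2[nH]c3ccc(C)cc3c2C=O)cc1` is methyl in place of methoxy on an aromatic carbon and puts methyl in place of methoxy on an aromatic carbon. Going by the values given here, the one measured step that bears on it is a 2.5-fold lower number from compound 2 to compound 3 (0.39 log units; beyond the scatter) where chloro replaced methoxy at another carbon of the core. Among the compounds with values here, no measured step involves methyl, so only a small move to a lower number is expected. The estimated step is a 1.6-fold lower number from compound 1 to compound 4 (0.21 log units; within the scatter) and it stays an expectation. For compound 4 the estimated value is 110 nM with an expected range from 50 nM to 240 nM in this assay.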

Compound 4, half-maximal inhibitory concentration: 140 nM
Beside the measured number, compound 4's estimate is 1.3-fold (0.10 log units) below it; the range from low to high includes it.
By their numbers in this assay, from the lowest: compound 3; then compounds 4, 2 and 1 (each within the scatter of the next).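

At this position of the shared core, methyl in place of methoxy gives a 1.3-fold lower number from compound 1 to compound 4 (0.11 log units; within the scatter) in this assay, so a group with no hydrogen-bond acceptor replaces one with a hydrogen-bond acceptor without a step beyond the scatter. The earlier compounds shown here showed a change only at another carbon of the core, and with chloro rather than methyl. Nothing measured here accounts for this result. The compounds shown leave open what chloro would do at this carbon, and how an amine or a carboxylic acid would read here.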